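This account rests on a few compounds, and the source may have more. Where it says the series, first, only, none or still open, it means among the compounds named here.

In an assay on isolated protein for inhibition of phosphatidylinositol 4,5-bisphosphate 3-kinase catalytic subunit beta isoform (Homo sapiens) (a higher number here means a weaker inhibitor, a lower number a stronger inhibitor), three close relatives of a single sulfonamide-bearing core have been measured. Compound 1 `CC1(C)CCN1S(=O)(=O)c1cncc(-c2ccn3nc(N)nc3c2)c1` gives 50100000 nM; compound 2 `CNS(=O)(=O)c1cncc(-c2ccn3nc(N)nc3c2)c1` gives 39800000 nM; compound 3 `Nc1nc2cc(-c3cncc(S(=O)(=O)Nc4ccccc4)c3)ccn2n1` gives 31600000 nM. Compound 3 holds the lowest of the three numbers, but its steps to the other two are small: the changes run a 1.3-fold lower number from compound 1 to compound 2 (0.10 log units; within the scatter), a 1.6-fold lower number from compound 1 to compound 3 (0.20 log units; within the scatter) and a 1.3-fold lower number from compound 2 to compound 3 (0.10 log units; within the scatter), and all three sit within the scatter of repeated runs, so no one of these compounds can be ranked against another.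

Compound 4 `Nc1nc2cc(-c3cncc(S(=O)(=O)NCc4ccccc4)c3)ccn2n1` has not yet been tested in this assay. It differs from compound 3 only at the sulfonamide nitrogen: benzyl in place of phenyl on a sulfonamide nitrogen. The step that bears most directly on this change is the one in which the same nitrogen was altered, a 1.3-fold lower number from compound 2 to compound 3 (0.10 log units; within the scatter), and the steps from compound 1 likewise show that swapping the group on the sulfonyl sulfur moved the number little. The expected change is therefore no change at the digits printed from compound 3 to compound 4 (within the scatter), none beyond the scatter. On that basis compound 4 is estimated at 31600000 nM in this assay, with a range from 10000000 nM to 100000000 nM.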

Compound 4, half-maximal inhibitory concentration: 25100000 nM
Beside the measured number, compound 4's estimate is 1.3-fold (0.10 log units) above it; low and high end bracket the measured number.
By their numbers in this assay, from the lowest: compounds 4, 3, 2 and 1 (each within the scatter of the next).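

In this assay, benzyl in place of phenyl on a sulfonamide nitrogen gives a 1.3-fold lower number from compound 3 to compound 4 (0.10 log units; within the scatter), so the group on this nitrogen can take a saturated chain carbon ahead of its aromatic ring without the number leaving the scatter. Phenyl in place of hydrogen on that chain carbon gives a 1.6-fold lower number from compound 2 to compound 4 (0.20 log units; within the scatter), and exchanging the whole group on the sulfonyl sulfur gives a 2.0-fold lower number from compound 1 to compound 4 (0.30 log units; within the scatter), so compound 4 cannot be ranked against any of the other three and this position still shows no step beyond the scatter. Nothing available offers an explanation for this flat result.

The compounds shown leave open whether any other group on this nitrogen, such as a carboxylic acid, a primary amine or a longer chain ending in phenyl, would move the number beyond the scatter. They also leave open how the number responds to changes in the shared core, which all four compounds keep.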